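Replacing the thiophene with a trifluoromethylphenyl on the imine

The source may report more compounds than this note shows. Statements on the series, on what has been measured and on what is new or still open speak of the compounds shown alone.

Of the compounds shown here, three of this set have been measured in a functional assay on HCT-116 cells (Homo sapiens) for antiproliferative activity, read by MTT assay; on this read-out lower numbers stand for stronger inhibition and higher numbers for weaker inhibition. Compound 1 `CCOC(=O)/C=N/c1cnc(Nc2ccc(S(N)(=O)=O)cc2)nc1NC(C)C` gives 49100 nM. Compound 3 `CC(C)Nc1nc(Nc2ccc(S(N)(=O)=O)cc2)ncc1/N=C/c1cccs1` gives 82100 nM, the highest of the two numbers obtained; its nearest neighbour is compound 1, separated by a 1.7-fold higher number from compound 1 to compound 3 (0.22 log units; within the scatter). For compound 2 `CC(C)Nc1nc(Nc2ccc(S(N)(=O)=O)cc2)ncc1/N=C/c1ccccc1` the assay reports only a limit, > 100000 nM. The step of an at least 1.2-fold lower number from compound 2 to compound 3 (0.08 log units; that floor lies within the scatter) likewise stays within the scatter.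

Compound 4 `CC(C)Nc1nc(Nc2ccc(S(N)(=O)=O)cc2)ncc1/N=C/c1ccc(C(F)(F)F)cc1` differs from compound 3 by 4-(trifluoromethyl)phenyl in place of thiophen-2-yl on a carbon with a double bond to nitrogen. The step that bears on it most directly is the one between the phenyl and the thiophen-2-yl imines, an at least 1.2-fold lower number from compound 2 to compound 3 (0.08 log units; that floor lies within the scatter), and the step of an at least 2.0-fold higher number from compound 1 to compound 2 (0.30 log units; that floor lies within the scatter) shows that the phenyl imine reached the limit (the limit of > 100000 nM in this assay, at which 1 of the 3 values shown sits). Returning to a six-membered carbon ring, now carrying a trifluoromethyl, is therefore expected to leave the number where it is or push it slightly upward, with a 1.2-fold higher number from compound 3 to compound 4 (0.09 log units; within the scatter) as the expected step. Compound 4 is accordingly estimated at 100000 nM, between 50000 nM and 200000 nM, with a real chance that only a limit is reported.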

Compound 4, half-maximal inhibitory concentration: > 100000 nM
Compound 4 ended at the assay's limit; the forecaster's own chance of this, stated with the estimate: 45%; the middle value sits exactly at the limit.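

Compound 4 is a second imine on this carbon whose result is only a limit, alongside compound 2, and a limit is all this assay gives for it: the limit of > 100000 nM in this assay, at which 2 of the 4 values shown sit. Against the thiophen-2-yl imine the change gives an at least 1.2-fold higher number from compound 3 to compound 4 (0.08 log units; that floor lies within the scatter), and against the ethoxycarbonyl imine it gives an at least 2.0-fold higher number from compound 1 to compound 4 (0.30 log units; that floor lies within the scatter), so neither comparison separates compound 4 from the other compound beyond the scatter. The step from compound 2 to compound 4, trifluoromethyl in place of hydrogen on an aromatic carbon, cannot be read, as both values are limits.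

The compounds shown leave open what trifluoromethyl itself does on the phenyl ring at this position. They also leave open whether a pyridine ring, a methoxy group on the phenyl or a carboxylic acid on this carbon would move the number beyond the scatter.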